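The compounds below may be only part of what the source reports. "The series", "measured", "known", "first", "only" and "open" are said of these compounds alone.

Measured compounds:
Compound 1 `N#CC1=C(N)Oc2c(c3nc4ccccc4nc3c3ccccc23)C12C(=O)N(Cc1cnnn1-c1ccc(N)cc1)c1ccccc12`: > 50000 nM
Compound 2 `N#CC1=C(N)Oc2c(N)cc3nc4ccccc4nc3c2C12C(=O)N(Cc1cnnn1-c1cccc(C(F)(F)F)c1)c1ccccc12`: 15800 nM

For the measured compounds named here, in a functional assay on HepG2 cells (Homo sapiens) for antiproliferative activity, read by MTT assay, with a stated time of 48 h (a lower number here means a stronger inhibitor, a higher number a weaker inhibitor), compound 2 gives 15800 nM, the only plain number recorded here. For compound 1 the result is not a number but a limit of the assay, (the limit of > 50000 nM in this assay, at which 1 of the 2 values shown sits). Compound 3 `N#CC1=C(N)Oc2c(N)cc3nc4ccccc4nc3c2C12C(=O)N(Cc1cnnn1-c1c(Cl)cc(Cl)cc1Cl)c1ccccc12` has not yet been tested; it differs from compound 2 in one place: 2,4,6-trichlorophenyl in place of 3-(trifluoromethyl)phenyl on an aromatic nitrogen. No measured step of this kind is known among these compounds, so the expected step in this assay is small, within the usual scatter, with no clear direction. Compound 3 is therefore expected to give about 15000 nM, between 5000 nM and 50000 nM. That estimate means an expected step of a 1.1-fold lower number from compound 2 to compound 3 (0.02 log units; within the scatter).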

Compound 3, half-maximal inhibitory concentration: 37800 nM
Compound 3: the middle estimate sits 2.5-fold (0.40 log units) below what was measured; measured number inside the range.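

For the compounds shown here, this is the first measured step at this aromatic nitrogen. In this assay, 2,4,6-trichlorophenyl in place of 3-(trifluoromethyl)phenyl gives a 2.4-fold higher number from compound 2 to compound 3 (0.38 log units; beyond the scatter) and so shows that the aryl group here can modestly weaken the antiproliferative reading. Nothing measured here explains this step. From the compounds shown here alone, how a plain phenyl, a phenyl with a single chlorine or a small alkyl group such as methyl would read on this nitrogen remains open. So does whether the number of chlorines or their placement on the ring drives the step.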